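Working notes: methylphenyl isomers, compound 3 to compound 4

The compounds below may be only part of what the source reports. "The series", "measured", "known", "first", "only" and "open" are said of these compounds alone.

- compound 1 `CC(=O)N1CCC(C(=O)N2CCC(N3CCN(C(=O)c4cc(-c5ccccc5)nc(-c5ccc6[nH]ccc6c5)c4)CC3)CC2)CC1`: 46.5 10^-6 cm/s
- compound 2 `CC(=O)N1CCC(C(=O)N2CCC(N3CCN(C(=O)c4cc(-c5ccc(F)cc5)nc(-c5ccc6[nH]ccc6c5)c4)CC3)CC2)CC1`: 44.3 10^-6 cm/s
- compound 3 `CC(=O)N1CCC(C(=O)N2CCC(N3CCN(C(=O)c4cc(-c5cccc(C)c5)nc(-c5ccc6[nH]ccc6c5)c4)CC3)CC2)CC1`: 28.1 10^-6 cm/s
- compound 4 `CC(=O)N1CCC(C(=O)N2CCC(N3CCN(C(=O)c4cc(-c5ccc(C)cc5)nc(-c5ccc6[nH]ccc6c5)c4)CC3)CC2)CC1`: not yet measured

In an ADME assay for permeability, using PAMPA (on this read-out lower numbers stand for lower permeability and higher numbers for higher permeability), compound 3 gives 28.1 10^-6 cm/s, which stands within the scatter of the other two values. The series so far shows no clear separation among these compounds.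

The next change is 4-methylphenyl in place of 3-methylphenyl on an aromatic carbon, next to the ring nitrogen of a six-membered aromatic ring with 1 nitrogen. The two compounds have the same atoms, joined differently. For the measured compounds named here, no measured pair shows this exchange directly, so the evidence is indirect.

Going by the values given here, three measured steps bear on it. Methyl in place of hydrogen gives a 1.7-fold lower number from compound 1 to compound 3 (0.22 log units; within the scatter). Fluoro in place of hydrogen gives a 1.0-fold lower number from compound 1 to compound 2 (0.02 log units; within the scatter). The exchange of 4-fluorophenyl for 3-methylphenyl gives a 1.6-fold lower number from compound 2 to compound 3 (0.20 log units; within the scatter). None of these leaves the scatter, so no step beyond the scatter is expected in this assay, and any direction is only weakly indicated.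

The estimated step is a 1.2-fold higher number from compound 3 to compound 4 (0.10 log units; within the scatter). For compound 4 the expected value is 35 10^-6 cm/s, with an estimated range from 20 10^-6 cm/s to 55 10^-6 cm/s.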

Compound 4, apparent permeability: 39.8 10^-6 cm/s
Compound 4: middle estimate off by 1.1-fold (0.06 log units), on the low side; the measured number falls inside the stated range.
By their numbers in this assay, from the lowest: compounds 3, 4, 2 and 1 (each within the scatter of the next).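

Exchanging 3-methylphenyl for 4-methylphenyl, with the same atoms joined differently, can now be read directly in this assay: a 1.4-fold higher number from compound 3 to compound 4 (0.15 log units; within the scatter), so moving the methyl around this phenyl ring does not separate the two isomers. The 4-methylphenyl compound is also not separated from the other two compounds, with a 1.1-fold lower number from compound 2 to compound 4 (0.05 log units; within the scatter) for methyl in place of fluoro and a 1.2-fold lower number from compound 1 to compound 4 (0.07 log units; within the scatter) for methyl in place of hydrogen, so all four aryl groups on this aromatic carbon of the six-membered aromatic ring with 1 nitrogen remain within the scatter of one another. No measurement is available that would account for these small differences.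

For the compounds shown here, the groups at this place so far are phenyl, 4-fluorophenyl, 3-methylphenyl and 4-methylphenyl, so it remains open whether an amine, a carboxylic acid or a longer chain on that phenyl ring would give a step beyond the scatter. From the compounds shown here alone, the 1H-indol-5-yl group and the rest of the shared core are the same in all four compounds, so it also remains open whether this flat picture would hold with a different group in those places.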